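A few compounds are considered here, and "the series" means these few. Any claim that something is new, unique, unknown or untested is made for them only; others in the source may bear on it.

Compound 1 `CCCCCOC(=O)CCC(=O)N1CCN(CCCOc2cc3c(Nc4ccc(F)c(Cl)c4)ncnc3cc2OC)CC1`: 30%
Compound 2 `CCCCCCOC(=O)CCC(=O)N1CCN(CCCOc2cc3c(Nc4ccc(F)c(Cl)c4)ncnc3cc2OC)CC1`: 63.6%

In a functional assay on A549 cells (Homo sapiens) for cytotoxicity, read by MTT assay, with a stated time of 24 h, tested at 60 uM (a higher number here means a weaker effect of the compound at the concentration tested, a lower number a stronger effect), compound 2 stands highest of the two numbers; its nearest neighbour, compound 1, lies lower beyond the scatter. Compound 3 `CCCCCCCOC(=O)CCC(=O)N1CCN(CCCOc2cc3c(Nc4ccc(F)c(Cl)c4)ncnc3cc2OC)CC1` continues the same change one carbon further: methyl in place of hydrogen on a saturated chain carbon, six bonds along the chain from an oxygen next to a carbonyl group. For the measured compounds named here, the single measured step that bears on it is a number 33.6 percentage points higher from compound 1 to compound 2 (beyond the scatter), a large rise. Compound 3 is therefore expected to show a smaller rise in the same direction, estimated as a number 11.4 percentage points higher from compound 2 to compound 3 (beyond the scatter). The estimate for compound 3 is 75%, with a range from 52% to 95%.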

Compound 3, a percentage reported as activity, at one concentration (the size of the read-out at that concentration, not a potency): 35.7%
The estimate for compound 3 lay 39.3 percentage points above the measured number; the measured number lies below the stated range.
By their numbers in this assay, from the lowest: compounds 1 and 3 (each within the scatter of the next); then compound 2.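

In this assay the methyl six bonds along the chain from an oxygen next to a carbonyl group turns the earlier rise around, giving a number 27.9 percentage points lower from compound 2 to compound 3 (beyond the scatter) and showing that the same change does not act in one direction along this chain. The ethyl in place of hydrogen, five bonds along, gives a number 5.7 percentage points higher from compound 1 to compound 3 (within the scatter) and so shows no steady trend with chain length across these compounds, with compound 2 going against one. Nothing available here explains this turn.

The compounds shown leave open whether a longer chain would stay with compound 3 or swing back towards compound 2. They also leave open how a branched chain or a chain ending in a carboxylic acid would read at this place.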